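Swapping 2-hydroxyethyl for isopropyl on the amide

The source may hold more compounds than are shown below. What is called first, only, known or untested is meant among the compounds shown, and "the series" means these compounds.

Values in a functional assay on A549 cells (Homo sapiens) for cytotoxicity, read by MTT assay, with a stated time of 72 h; on this read-out higher numbers stand for weaker inhibition and lower numbers for stronger inhibition:
Compound 1 `Cc1oc2ncnc(Nc3cccc(Br)c3)c2c1C(=O)O`: 43000 nM
Compound 2 `Cc1oc2ncnc(Nc3cccc(Cl)c3)c2c1C(=O)NCCO`: > 1000000 nM

Compound 2 stands at the edge of what the numbers can show. Its reading in this assay of > 1000000 nM is a limit of the assay and not a number.

Within the data shown here, no two measured compounds differ in one place only, so no measured step is available as a guide. The next compound, compound 3 `Cc1oc2ncnc(Nc3cccc(Cl)c3)c2c1C(=O)NC(C)C`, carries isopropyl in place of 2-hydroxyethyl on an amide-type nitrogen. The rest of compound 2 stays as it is.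

The expectation is therefore a loose one. Among the measured compounds shown here, the only numeric reading so far is that of compound 1 at 43000 nM, and this sets the rough scale. Some move towards stronger inhibition in this assay is expected, although another reading at the limit would not be surprising. The expected size and direction are given by the estimated at least 5.0-fold lower number from compound 2 to compound 3 (0.69 log units; beyond the scatter). For compound 3 the estimated value is 200000 nM, with an expected range of 30000 nM to 1000000 nM.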

Compound 3, half-maximal inhibitory concentration: > 1000000 nM
Compound 3: a limit, no number (the forecaster's own chance of this, stated with the estimate: 35%); middle value at least 5.0-fold (0.69 log units) away from the limit.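

Among these compounds, compound 2 and compound 3 both rest on a limit of the assay rather than on a number, and no step between them can be read: the limit of > 1000000 nM in this assay, at which 2 of the 3 values shown sit. The compounds shown leave open whether isopropyl and 2-hydroxyethyl on the amide-type nitrogen differ at all in this assay.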